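Trading the dichlorophenoxyethyl amide of compound 2 for methylphenoxymethyl

The source may report more compounds than this note shows. Statements on the series, on what has been measured and on what is new or still open speak of the compounds shown alone.

Measured compounds:
Compound 1 `CCN1CCN(c2cc(C)c3cc(NC(=O)CSc4ccncc4)ccc3n2)CC1`: 8200 nM
Compound 2 `CCN1CCN(c2cc(C)c3cc(NC(=O)C(C)Oc4ccc(Cl)cc4Cl)ccc3n2)CC1`: 230 nM
Compound 3 `Cc1cc(N2CCN(C)CC2)nc2ccc(NC(=O)C(C)Oc3ccc(Cl)cc3Cl)cc12`: 790 nM

In an assay on CHO cells for inhibition of melanin-concentrating hormone receptor 1 (Homo sapiens) (a higher number here means a weaker inhibitor, a lower number a stronger inhibitor), compound 2 holds the lowest number of the three. Its nearest neighbour is compound 3, reached by a 3.4-fold higher number from compound 2 to compound 3 (0.54 log units; beyond the scatter); its furthest is compound 1, from which it is separated by a 36-fold lower number from compound 1 to compound 2 (1.55 log units; beyond the scatter).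

Compound 4 `CCN1CCN(c2cc(C)c3cc(NC(=O)COc4cccc(C)c4)ccc3n2)CC1` is not yet measured. It differs from compound 2 in a single place: (3-methylphenoxy)methyl in place of 1-(2,4-dichlorophenoxy)ethyl on a carbonyl carbon.

Going by the values given here, of the two measured steps, only the one from compound 1 to compound 2 alters the group on the carbonyl carbon, and there the change was large, a 36-fold lower number from compound 1 to compound 2 (1.55 log units; beyond the scatter). The step from compound 2 to compound 3 concerns the amine nitrogen in a ring, not the amide side, so it speaks only indirectly. Compound 4 keeps a phenoxy-type group on the carbonyl carbon, so a shift as large as that from compound 1 to compound 2 seems unlikely, yet the two chlorines and the methyl branch of the group in compound 2 are lost, so a modest rise in this assay is expected, a 3.0-fold higher number from compound 2 to compound 4 (0.48 log units; beyond the scatter). Compound 4 is therefore estimated at 700 nM in this assay, with a plausible range from 200 nM to 2500 nM.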

Compound 4, half-maximal inhibitory concentration: 6600 nM
For compound 4 the middle estimate is 9.4-fold (0.97 log units) below the measured one; measured number outside the range, above it.
By their numbers in this assay, from the lowest: compound 2; then compound 3; then compounds 4 and 1 (each within the scatter of the next).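

In this assay, keeping an aryl ether on the carbonyl carbon does not by itself keep the number low: a 29-fold higher number from compound 2 to compound 4 (1.46 log units; beyond the scatter), a large step for (3-methylphenoxy)methyl in place of 1-(2,4-dichlorophenoxy)ethyl. The comparison with the sulfur-linked pyridine group gives a 1.2-fold lower number from compound 1 to compound 4 (0.09 log units; within the scatter), so 3-methylphenoxy and (pyridin-4-yl)sulfanyl on the saturated chain carbon bound to a carbonyl carbon cannot be told apart here. Among these three amides on the same ethylpiperazine-bearing side of the molecule, the low number therefore goes with the 1-(2,4-dichlorophenoxy)ethyl group of compound 2 rather than with the phenoxy oxygen alone.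

The step from compound 2 to compound 4 removes the two chlorines and the chain methyl and adds the ring methyl all at once, so the compounds shown do not assign the change to any one of these. From the compounds shown here alone, whether (2,4-dichlorophenoxy)methyl or 1-(3-methylphenoxy)ethyl would sit nearer to compound 2 or to compound 4 stays open, as does the effect of an amine or a carboxylic acid on the phenyl ring. No evidence at hand bears on what lies behind this step.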